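Methyl for hydroxy on the benzyl ring of compound 3

A few compounds are considered here, and "the series" means these few. Any claim that something is new, unique, unknown or untested is made for them only; others in the source may bear on it.

Compound 3 `Oc1ccc(CNc2cc(Br)cc3[nH]ncc23)cc1O` gives 50% in an assay for inhibition of Indoleamine 2,3-dioxygenase 1 (Homo sapiens), with a stated time of 1 h, tested at 10 uM; on this read-out higher numbers stand for more inhibition at the one concentration tested (going by the name of the read-out) and lower numbers for less inhibition. Compound 1 `Oc1cccc(CNc2cc(Br)cc3[nH]ncc23)c1` gives 45%, a number that compound 3 matches within the scatter, while compound 2 `NS(=O)(=O)c1ccc(CNc2cc(Br)cc3[nH]ncc23)cc1` with 20% lies well below both. The next compound is compound 4 `Cc1cc(CNc2cc(Br)cc3[nH]ncc23)ccc1O`, which differs from compound 3 by methyl in place of hydroxy on an aromatic carbon. Among the measured compounds shown here, the only measured step that touches this site is the one from compound 1 to compound 3, a number 5 percentage points higher from compound 1 to compound 3 (within the scatter), which did not leave the scatter. Taking the hydroxy away again, and putting a methyl in its place, is thus expected to move the number little. The expected step is a number 5 percentage points lower from compound 3 to compound 4 (within the scatter), not beyond the scatter. Compound 4 is therefore estimated at 45%, within 25% to 65%.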

Compound 4, a percentage reported as inhibition, at one concentration (the size of the read-out at that concentration, not a potency): 28%
Beside the measured number, compound 4's estimate is 17 percentage points above it; the measured number falls inside the stated range.
By their numbers in this assay, from the lowest: compounds 2 and 4 (each within the scatter of the next); then compounds 1 and 3 (each within the scatter of the next).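

In this assay, swapping hydroxy for methyl on this aromatic carbon, ortho to a hydroxy group and meta to a large group, gives a number 22 percentage points lower from compound 3 to compound 4 (beyond the scatter). Among the compounds shown here, the only earlier step on this benzyl ring, a hydroxy added in a number 5 percentage points higher from compound 1 to compound 3 (within the scatter), stayed small, so this carbon responds to a single-atom change in a way that step did not show. Nothing available explains the drop. On these data alone, it remains open whether losing the hydroxy or gaining the methyl drives the drop, and how an amine or a methoxy group would behave on this carbon.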